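This account rests on a few compounds, and the source may have more. Where it says the series, first, only, none or still open, it means among the compounds named here.

Working notes on the series in an ADME assay on HepG2 2.2.15 cells (Homo sapiens) for cytotoxicity; on this read-out lower numbers stand for higher toxicity in this test and higher numbers for lower toxicity in this test. Three compounds carry a result so far. Compound 1 `O=C(Nc1ncc(Cc2ccc(Cl)cc2)s1)c1ccc(F)cc1F` gives "not toxic" (no number reported). Compound 3 `Clc1ccc(C(Oc2ccc3cc(Br)ccc3c2)c2cnc(NCC3CCCCC3)s2)cc1` likewise gives "not toxic" (no number reported), so no single number stands for it, and it sits alongside the other entries without a figure. Compound 2 `CC(C)(C)OC(=O)Nc1ncc(C(Oc2ccc(F)c(Cl)c2)c2ccc(Cl)cc2)s1` gives > 50000 nM, which is a limit of this assay and not a number. Across the set, then, the only marked point is the limit of > 50000 nM in this assay, at which 1 of the 3 values shown sits, and nothing else separates the three entries.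

Among the measured compounds shown here, no step between two measured compounds exists, so no measured step size can be quoted. The step from compound 3 to compound 4 `CCOC(=O)CCCNc1ncc(C(Oc2ccc3cc(Br)ccc3c2)c2ccc(Cl)cc2)s1` consists of 2-(ethoxycarbonyl)ethyl in place of cyclohexyl on a saturated chain carbon bound to a nitrogen on an aromatic ring, in words: 2-(ethoxycarbonyl)ethyl in place of cyclohexyl on a saturated chain carbon bound to a nitrogen on an aromatic ring.

In this assay no change beyond the scatter is expected for this step; every entry so far reports either a limit or an absence of toxicity, and nothing among compounds 1, 2 and 3 points in a direction. Compound 4 is therefore estimated at 50000 nM, with a range of 15000 nM to 150000 nM, and the outcome is expected most often to be reported only as a limit.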

Compound 4, half-maximal cytotoxic concentration: "not toxic" (no number reported)
For compound 4 the study gives words and no number, so the estimate cannot be set against anything.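

Compound 3 and compound 4 both carry words and no number in this assay, so no new step can be read from this pair. The compounds shown leave open at what concentration, if any, cytotoxicity appears for either of them, and whether 2-(ethoxycarbonyl)ethyl in place of cyclohexyl changes this read-out at all.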